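The compounds below may be only part of what the source reports. "The series", "measured", "known", "first", "only" and "open" are said of these compounds alone.

Measured in an ADME assay on L02 cells (Homo sapiens) for cytotoxicity, read by MTT assay; on this read-out lower numbers stand for stronger inhibition and higher numbers for weaker inhibition:
- Compound 1 `COc1ccc(/C=C/C(=O)c2ccc(OC)c3c2OC(C)(C)C=C3)cc1O`: > 10000 nM (a limit)
- Compound 2 `COc1ccc(/C=C/C(=O)c2ccc(OC)c3c2OC(C)(C)C=C3)cc1OCCCN(C)C`: 8600 nM
- Compound 3 `COc1ccc(/C=C/C(=O)c2ccc(OC)c3c2OC(C)(C)C=C3)cc1OC(=O)CCl`: > 10000 nM (a limit)

Compound 3 gives > 10000 nM in this assay, which is a limit of the assay and not a number. The next compound, compound 4 `COc1ccc(/C=C/C(=O)c2ccc(OC)c3c2OC(C)(C)C=C3)cc1CS(C)(=O)=O`, carries (methylsulfonyl)methyl in place of ((chloromethyl)carbonyl)oxy on an aromatic carbon, ortho to a methoxy group: (methylsulfonyl)methyl in place of ((chloromethyl)carbonyl)oxy on an aromatic carbon.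

Among the measured compounds shown here, three measured steps bear on this change, though each alters only the group on the oxygen that compound 4 no longer has. Adding 3-(dimethylamino)propyl gave an at least 1.1-fold lower number from compound 1 to compound 2 (0.06 log units; that floor lies within the scatter). Exchanging that chain for (chloromethyl)carbonyl gave an at least 1.1-fold higher number from compound 2 to compound 3 (0.06 log units; that floor lies within the scatter). The remaining comparison is a step that the two limits leave unreadable from compound 1 to compound 3.

None of these steps points to a large move, and compound 4 is expected to stay close to the limit of > 10000 nM in this assay, at which 2 of the 3 values shown sit. No change beyond the scatter is expected, and the estimated step is a number no higher from compound 3 to compound 4 (the limit leaves the size open). For compound 4 the estimated value is 10000 nM, with an expected range from 5000 nM to 20000 nM.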

Compound 4, half-maximal inhibitory concentration: > 10000 nM
Compound 4 ended at the assay's limit (the forecaster's own chance of this, stated with the estimate: 65%); the middle value lies on the limit itself.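

Among the compounds shown here, until this result, every change at this position kept the oxygen on the aromatic carbon and altered only what was attached to it, whereas (methylsulfonyl)methyl removes that oxygen and attaches through carbon. Even with this different link, the compound stays at the top of the measurable range in this assay, so the limit now covers one more compound: the limit of > 10000 nM in this assay, at which 3 of the 4 values shown sit.

For the compounds shown here, the one readable comparison is an at least 1.1-fold higher number from compound 2 to compound 4 (0.06 log units; that floor lies within the scatter), while the steps to compound 4 from compound 1 and from compound 3 join two limits and cannot be read.

As far as these compounds go, how far the true values of compound 1, compound 3 and compound 4 lie past the limit remains unknown, so these compounds cannot be ranked against one another. From the compounds shown here alone, it also remains open whether a carboxylic acid or a longer chain ending in a piperidine at this position would give a change beyond the scatter.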